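Lengthening the second chain of compound 1

A few compounds are considered here, and "the series" means these few. Any claim that something is new, unique, unknown or untested is made for them only; others in the source may bear on it.

Compound 1 `CCCCCCCCCCCO[C@@H]1[C@@H](N)[C@@H](O[C@H]2[C@H](O)[C@@H](OCCCCCCC)[C@H](N)C[C@@H]2N)O[C@H](CN)[C@H]1O` carries a longer chain on one side of its shared core and a shorter one on the other. In an ADME assay on J774 cells (Mus musculus) for cytotoxicity, read by MTT assay, with a stated time of 24 h, tested at 10 uM (a higher number here means a weaker effect of the compound at the concentration tested, a lower number a stronger effect), compound 1 gives 88.4%. Among the three numbers measured, this sits second highest: compound 2 `NC[C@H]1O[C@H](O[C@H]2[C@H](O)[C@@H](O)[C@H](N)C[C@@H]2N)[C@H](N)[C@@H](OCCCc2ccc3ccccc3c2)[C@@H]1OCCCc1ccc2ccccc2c1` gives 87.7%, and compound 3 `CCCCCCCO[C@@H]1[C@@H](N)[C@@H](O[C@H]2[C@H](O)[C@@H](OCCCCCCC)[C@H](N)C[C@@H]2N)O[C@H](CN)[C@H]1O` gives 96.3%, both within the scatter of compound 1.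

The unmeasured compound 4 `CCCCCCCCCCCO[C@@H]1[C@@H](N)[C@@H](O[C@H]2[C@H](O)[C@@H](OCCCCCCCCCCC)[C@H](N)C[C@@H]2N)O[C@H](CN)[C@H]1O` differs from compound 1 by butyl in place of hydrogen on a saturated chain carbon, seven bonds along the chain from an oxygen on a saturated carbon, so that both chains now match the longer one. For the measured compounds named here, the one measured step that bears on this is the mirror image of it: a number 7.9 percentage points higher from compound 1 to compound 3 (within the scatter), where the same kind of chain was shortened rather than lengthened and the number stayed within the scatter. With a single step of that size in hand, no change beyond the scatter is expected from adding the butyl on the other chain; the estimated step is a number 4.4 percentage points lower from compound 1 to compound 4 (within the scatter).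

For compound 4 in this assay the expected value is 84%, with a range from 68% to 98%.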

Compound 4, a percentage reported as activity, at one concentration (the size of the read-out at that concentration, not a potency): 81.7%
Beside the measured number, compound 4's estimate is 2.3 percentage points above it; the measured number falls inside the stated range.
By their numbers in this assay, from the lowest: compounds 4, 2, 1 and 3 (each within the scatter of the next, the first and the last beyond it).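

Placing butyl in place of hydrogen on a saturated chain carbon, seven bonds along the chain from an oxygen on a saturated carbon, gives in this assay a number 6.7 percentage points lower from compound 1 to compound 4 (within the scatter), so this position accepts the added butyl without a step beyond the scatter. Read with the earlier step, a number 7.9 percentage points higher from compound 1 to compound 3 (within the scatter), this shows that neither adding butyl to one chain of compound 1 nor removing it from the other moves the number beyond the scatter at the one concentration tested. No measurement is available that would explain the size of this step.

Going by these compounds, it remains open whether a longer chain, or a chain ending in an amine or a carboxylic acid, would stay within the scatter at this position. The response of these compounds at other concentrations also remains open.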